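Methyl to methoxy on the benzyl arm

The source may report more compounds than this note shows. Statements on the series, on what has been measured and on what is new or still open speak of the compounds shown alone.

In a physicochemical assay for solubility, in phosphate buffer (on this read-out higher numbers stand for higher solubility and lower numbers for lower solubility), compound 3 (`Cc1ccc(CNCCCC[C@@H](Nc2cc(C)c(F)c(C)c2)C(=O)NO)cc1`) stands at > 5 ug/mL as a limit, not a number. Compound 1 (`Cc1cc(CNCCCC[C@@H](Nc2cc(C)c(F)c(C)c2)C(=O)NO)ccc1F`) gives > 5 ug/mL as a limit too. Compound 2 (`Cc1cc(N[C@H](CCCCNCc2ccccc2F)C(=O)NO)cc(C)c1F`) gives > 5 ug/mL as a limit as well. Compound 4 (`COc1ccc(CNCCCC[C@@H](Nc2cc(C)c(F)c(C)c2)C(=O)NO)cc1`) carries methoxy in place of methyl on an aromatic carbon, para to a large group (methoxy in place of methyl on an aromatic carbon). Three measured steps alter this same group, namely a step that the two limits leave unreadable from compound 1 to compound 2 and a step that the two limits leave unreadable from compound 1 to compound 3 and a step that the two limits leave unreadable from compound 2 to compound 3 and their sizes stay unread because of the limit of > 5 ug/mL in this assay, at which 3 of the 3 values shown sit, here. No step beyond the scatter is therefore expected in this assay and no direction can be given. The expected step is a step that the limit leaves unreadable from compound 3 to compound 4 and no larger. Compound 4 is estimated at 9 ug/mL with an expected range from 5 ug/mL to 30 ug/mL in this read-out.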

Compound 4, solubility: > 5 ug/mL
Compound 4: no number, only a limit; the forecaster's own chance of this, stated with the estimate: 75%; the middle value does not contradict the limit.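

In this assay no new step can be read between compound 4 and compound 1, compound 2 or compound 3, because each value is only a limit: the limit of > 5 ug/mL in this assay, at which 4 of the 4 values shown sit.

The compounds shown leave open how the solubility of these four compounds compares, including whether methoxy and methyl differ at all.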